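Mirror-Image Configuration on the Butyl Chain Analogue

The compounds below may be only part of what the source reports. "The series", "measured", "known", "first", "only" and "open" are said of these compounds alone.

Of the compounds shown here, two have been measured in an assay on isolated protein for inhibition of lysosomal alpha-glucosidase (Homo sapiens); on this read-out higher numbers stand for weaker inhibition and lower numbers for stronger inhibition. Compound 1 `CCCCCCCCC[C@@]1(CO)NC[C@H](O)[C@H]1O` carries a nonyl chain on the shared core and in this assay gives 3700 nM. Compound 2 `CCCC[C@]1(CO)NC[C@@H](O)[C@@H]1O` carries a butyl chain and gives 79000 nM, the weaker of the two numbers, with compound 1 standing beyond the usual scatter below it. Among the measured compounds shown here, no single-change step between them is drawn, since they differ in chain and in configuration at once, so the values alone are all that can be said.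

Compound 3 `CCCC[C@@]1(CO)NC[C@H](O)[C@H]1O` is built from compound 2 by this change: the two compounds have the same atoms and bonds and differ only in configuration as drawn: 3 of 3 stereo elements differ (all stereocentres are inverted: mirror images); a stereocentre at a saturated ring carbon is drawn R in compound 2 and S in compound 3; a stereocentre at a saturated ring carbon is drawn R in compound 2 and S in compound 3; a stereocentre at a saturated ring carbon is drawn R in compound 2 and S in compound 3. Compound 3 therefore shares its drawn configuration with compound 1 while keeping the butyl chain of compound 2. On that basis compound 3 is expected to move toward stronger inhibition, with a step of a 9.9-fold lower number from compound 2 to compound 3 (0.99 log units; beyond the scatter) beyond the scatter, and its estimated value is 8000 nM, within a range from 1500 nM to 40000 nM.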

Compound 3, half-maximal inhibitory concentration: 2400 nM
For compound 3 the middle estimate is 3.3-fold (0.52 log units) above the measured one; the measured number falls inside the stated range.
By their numbers in this assay, from the lowest: compounds 3 and 1 (each within the scatter of the next); then compound 2.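

In this assay, among the compounds shown here, this mirror-image pair gives the first direct reading of configuration on the shared core, with a 33-fold lower number from compound 2 to compound 3 (1.52 log units; beyond the scatter). This large step can be assigned to configuration alone because nothing else separates the pair: the fact that compounds 2 and 3 differ only in the configuration as drawn

With the configuration held as drawn in compound 3, the change of chain, hydrogen in place of pentyl on a saturated chain carbon, four bonds along the chain from a saturated ring carbon, gives a 1.5-fold lower number from compound 1 to compound 3 (0.19 log units; within the scatter), so nonyl and butyl chains do not differ here beyond the scatter.

All three stereocentres invert together in this pair, which leaves open how much each one contributes. Also open, from the compounds shown here alone, is whether a much longer chain, such as dodecyl, or a phenyl ring in place of the chain would keep the same number in this configuration.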